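Two Thiophenes and a Difluorophenyl Analogue

The source may hold more compounds than are shown below. What is called first, only, known or untested is meant among the compounds shown, and "the series" means these compounds.

Compound 1 `Cc1sc(N)c(C(=O)c2ccc(Cl)cc2)c1-c1ccccc1`: 1%
Compound 2 `CC(C)(C)Cc1c(-c2ccoc2)sc(N)c1C(=O)c1ccc(Cl)cc1`: 1%

In an assay on CHO cells for displacement of a labelled ligand from adenosine receptor A1 (Homo sapiens), read by scintillation counting, tested at 10 uM (a higher number here means more inhibition at the concentration tested (going by the name of the read-out), a lower number less inhibition), compound 1 gives 1%. In this assay compound 2 gives 1%, level with compound 1 within the scatter; the inhibition in this assay is level for the two. Compound 3 `CC(C)(C)Cc1c(-c2ccc(F)cc2F)sc(N)c1C(=O)c1ccc(Cl)cc1` differs from compound 2 in one place: 2,4-difluorophenyl in place of furan-3-yl on an aromatic carbon. With both measured values level and low, no step beyond the scatter is expected in this assay, and the estimated step of a number 1 percentage points higher from compound 2 to compound 3 (within the scatter) is taken as none. Compound 3 is therefore expected to give 2%, within -6% to 12%.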

Compound 3, a percentage reported as inhibition, at one concentration (the size of the read-out at that concentration, not a potency): 1%
Compound 3: the middle estimate sits 1 percentage points above what was measured; the measured number falls inside the stated range.
By their numbers in this assay, from the lowest: compounds 1, 2 and 3 (each within the scatter of the next).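

In this assay, 2,4-difluorophenyl in place of furan-3-yl on the aromatic carbon next to the ring sulfur brings no change at the digits printed from compound 2 to compound 3 (within the scatter), so this position now carries a six-membered ring of carbon only as well as a five-membered ring with a hetero atom. The two rings read alike here, with compound 3 at 1% and inhibition still low. No measurement at hand bears on why they read alike. On these data alone, whether an amine or a carboxylic acid on this carbon would lift the number stays open, as does the effect of a longer chain in place of the neopentyl group.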